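The source may hold more compounds than are shown below. What is called first, only, known or untested is meant among the compounds shown, and "the series" means these compounds.

Among the measured compounds shown here, in a functional assay on the whole organism for antagonist activity, with Rattus norvegicus as the target (on this read-out higher numbers stand for an effect only at larger amounts of compound and lower numbers for an effect already at smaller amounts), compound 1 `c1ccc2c(c1)CC2CN1CCN(c2cccc3c2OCCO3)CC1` gives 0.67 mg/kg as the highest of the three numbers measured so far. Compound 2 `c1ccc2c(c1)CCC2CCCN1CCN(c2cccc3c2OCCO3)CC1` with 0.29 mg/kg and compound 3 `c1ccc2c(c1)CC(CCN1CCN(c3cccc4c3OCCO4)CC1)C2` with 0.27 mg/kg both lie lower, beyond the usual scatter, so they act at smaller doses. Compound 4 `Fc1cccc2c1CC2CN1CCN(c2cccc3c2OCCO3)CC1` is not yet measured and differs from compound 1 by a single change fluoro in place of hydrogen on an aromatic carbon with fluoro in place of hydrogen on an aromatic carbon. For the measured compounds named here, no measured pair shows this change in this assay so no step beyond the scatter is expected. The estimated step of a 1.3-fold lower number from compound 1 to compound 4 (0.13 log units; within the scatter) is therefore small. Compound 4 is expected at 0.5 mg/kg with 0.2 mg/kg to 1.3 mg/kg as its likely range.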

Compound 4, dose for 50% inhibition: 2.51 mg/kg
Beside the measured number, compound 4's estimate is 5.0-fold (0.70 log units) below it; the measured number lies above the stated range.
By their numbers in this assay, from the lowest: compounds 3 and 2 (each within the scatter of the next); then compound 1; then compound 4.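

In this assay, fluoro in place of hydrogen on an aromatic carbon, ortho to a fused ring, gives a 3.7-fold higher number from compound 1 to compound 4 (0.57 log units; beyond the scatter) and so an effect only at a larger dose. The earlier compounds shown here all carry hydrogen on their aromatic carbons, so only this result shows that this position responds to such a small change. No evidence here accounts for the shift. As far as these compounds go, whether chloro or methyl at this position would also raise the dose remains open. So does whether fluoro on another carbon of this ring would do the same.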